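This account rests on a few compounds, and the source may have more. Where it says the series, first, only, none or still open, it means among the compounds named here.

In a functional assay on MDA-MB-231 cells (Homo sapiens) for antiproliferative activity, read by MTT assay, with a stated time of 48 h (a higher number here means a weaker inhibitor, a lower number a stronger inhibitor), three compounds with a shared core have been measured. Compound 1 `C=CS(=O)(=O)N1CCN(c2ncnc3sc(-c4ccc(N5CCN(C)CC5)cc4)cc23)CC1` gives 7550 nM, and compound 2 `CN1CCN(c2ccc(-c3cc4c(N5CCN(S(=O)(=O)/C=C/c6ccccc6)CC5)ncnc4s3)cc2)CC1` gives 5900 nM. The sulfonyl change behind these values is small: a 1.3-fold lower number from compound 1 to compound 2 (0.11 log units; within the scatter). Compound 3 `COc1ccc(NC(=O)N2CCN(c3ncnc4sc(-c5ccc(N6CCN(C)CC6)cc5)cc34)CC2)cc1` gives 20900 nM, the highest number of the three, and it is the weakest of this set. Compound 4 `CN1CCN(c2ccc(-c3cc4c(N5CCN(C(=O)Nc6ccc(Cl)c(C(F)(F)F)c6)CC5)ncnc4s3)cc2)CC1` differs from compound 3 in one group: 4-chloro-3-(trifluoromethyl)phenyl in place of 4-methoxyphenyl on an amide-type nitrogen. This places 4-chloro-3-(trifluoromethyl)phenyl in place of 4-methoxyphenyl on an amide-type nitrogen.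

Going by the values given here, no measured step varies this aryl group, so the evidence is indirect. The closest steps replace the whole group on the ring nitrogen, and both are modest: a 2.8-fold higher number from compound 1 to compound 3 (0.44 log units; beyond the scatter), and a 3.5-fold higher number from compound 2 to compound 3 (0.55 log units; beyond the scatter). Those sizes suggest a modest change here too, and with compound 3 at the top of the measured values, a lower number is the likelier direction. The expected step is a 2.1-fold lower number from compound 3 to compound 4 (0.32 log units; beyond the scatter). For compound 4 the estimated value is 10000 nM, with an expected range of 3000 nM to 30000 nM.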

Compound 4, half-maximal inhibitory concentration: 2220 nM
For compound 4 the middle estimate is 4.5-fold (0.65 log units) above the measured one; measured number outside the range, below it.
By their numbers in this assay, from the lowest: compound 4; then compounds 2 and 1 (each within the scatter of the next); then compound 3.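

In this assay, the aryl group on the amide-type nitrogen turns out to matter in its own right: with the rest of the molecule unchanged, 4-chloro-3-(trifluoromethyl)phenyl in place of 4-methoxyphenyl gives a 9.4-fold lower number from compound 3 to compound 4 (0.97 log units; beyond the scatter). The carbamoyl link therefore does not by itself hold a compound at a high number, since compound 4 keeps that link and gives 2220 nM, whereas compound 2, with its sulfonyl group, gives 5900 nM. Nothing available explains this difference in terms of mechanism or properties.

The two substituents arrive together, so the compounds shown cannot tell whether the chlorine or the trifluoromethyl group carries the step. Also open, as far as these compounds go, is how this aryl position would respond to an unsubstituted phenyl, a nitrile, an amine or a carboxylic acid.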